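Removing a Methyl from a Pyridine-Thiosemicarbazide Growth Inhibitor

The source may report more compounds than this note shows. Statements on the series, on what has been measured and on what is new or still open speak of the compounds shown alone.

Three related compounds have been examined in a functional assay on HeLa cells (Homo sapiens) for cytotoxicity, read by MTT assay, with a stated time of 72 h, tested at 10 uM; on this read-out higher numbers stand for more inhibition of growth at the one concentration tested and lower numbers for less inhibition of growth. Compound 1 `N/C(=N\NC(=S)N1CCCCCC1)c1ccccn1` gives 67.4%. Compound 2 `Cc1ccnc(/C(N)=N/NC(=S)N2CCOCC2)c1` gives 49.1% in this assay. Compound 3 `Cc1cccc(/C(N)=N/NC(=S)N2CCSCC2)n1` gives 67.6% in this assay, the top figure of the three; compound 1 sits within the scatter of it, so the two cannot be told apart, while compound 2 lies beyond the scatter below it.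

Compound 4 `N/C(=N\NC(=S)N1CCSCC1)c1ccccn1` has not yet been tested. It differs from compound 3 only by hydrogen in place of methyl on an aromatic carbon, a hydrogen in place of methyl on an aromatic carbon of the core, at the position next to the ring nitrogen and meta to a large group. Within the data shown here, no measured pair in this set isolates that change alone, so there is no direct precedent for its size. A loss of a single carbon of this kind is expected to move the read-out little, with no step beyond the scatter in either direction, and the estimated step from compound 3 to compound 4 is a number 3.6 percentage points lower from compound 3 to compound 4 (within the scatter). Compound 4 is therefore expected to give about 64%, within a range from 50% to 78%.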

Compound 4, percent growth inhibition at one concentration: 54.5%
Compound 4: the middle estimate sits 9.5 percentage points above what was measured, within the range that was stated.
By their numbers in this assay, from the lowest: compounds 2 and 4 (each within the scatter of the next); then compounds 1 and 3 (each within the scatter of the next).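

In this assay, hydrogen in place of methyl on an aromatic carbon, at the place next to the ring nitrogen and meta to a large group, gives a number 13.1 percentage points lower from compound 3 to compound 4 (beyond the scatter), a step that stands out from ordinary repeat variation. Among these compounds, this is the first pair in the set to isolate this change, and it shows that a single carbon at this place can alter growth inhibition measurably. Nothing available here bears on why the number falls.

This is one pair, so it cannot show whether the methyl would matter as much on another compound of the series. With only methyl and hydrogen shown at this place, it remains open how a longer chain such as ethyl, or an amine, would read.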